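The source may hold more compounds than are shown below. What is called first, only, known or untested is meant among the compounds shown, and "the series" means these compounds.

Compound 1 `Nc1ccc(S(=O)(=O)N2CCN(c3ncc(C(O)(C(F)(F)F)C(F)(F)F)cc3C#CC3CC3)CC2)cn1`: 67 mL.min-1.g-1
Compound 2 `COCC#Cc1cc(C(O)(C(F)(F)F)C(F)(F)F)cnc1N1CCN(S(=O)(=O)c2ccc(N)nc2)CC1`: 399 mL.min-1.g-1
Compound 3 `CC(C)n1cc(-c2cc(C(O)(C(F)(F)F)C(F)(F)F)cnc2N2CCN(S(=O)(=O)c3ccc(N)nc3)CC2)cn1`: 198 mL.min-1.g-1

These values come from an ADME assay (liver) for metabolic stability, with Liver microsome (Rattus norvegicus) as the target, using microsomes and NADPH, with a stated time of 30 min, tested at 1 uM; a lower number here means slower removal, a higher number faster removal of the compound. Two steps place compound 3 among the others: a 3.0-fold higher number from compound 1 to compound 3 (0.47 log units; beyond the scatter), and a 2.0-fold lower number from compound 2 to compound 3 (0.30 log units; within the scatter). Compound 4 `Cc1csc(-c2cc(C(O)(C(F)(F)F)C(F)(F)F)cnc2N2CCN(S(=O)(=O)c3ccc(N)nc3)CC2)c1` has 4-methylthiophen-2-yl in place of 1-isopropyl-1H-pyrazol-4-yl on an aromatic carbon. Among the compounds with values here, no measured step makes this exact swap. The nearest evidence is those same two steps, which also changed the group at this place, and they were modest or within the scatter. Both groups are five-membered aromatic rings, and no step beyond the scatter is expected. The expected step is a 1.3-fold higher number from compound 3 to compound 4 (0.10 log units; within the scatter). For compound 4 the estimated value is 250 mL.min-1.g-1, with an expected range of 105 mL.min-1.g-1 to 590 mL.min-1.g-1.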

Compound 4, intrinsic clearance in microsomes: 399 mL.min-1.g-1
Beside the measured number, compound 4's estimate is 1.6-fold (0.20 log units) below it; the measured number falls inside the stated range.
By their numbers in this assay, from the lowest: compound 1; then compounds 3, 2 and 4 (each within the scatter of the next).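

In this assay, 4-methylthiophen-2-yl at this position gives a 2.0-fold higher number from compound 3 to compound 4 (0.30 log units; within the scatter) and no change at the digits printed from compound 2 to compound 4 (within the scatter) so this five-membered aromatic ring cannot be told apart from 1-isopropyl-1H-pyrazol-4-yl or 3-methoxyprop-1-yn-1-yl. Against 2-cyclopropylethynyl it gives a 6.0-fold higher number from compound 1 to compound 4 (0.77 log units; beyond the scatter) and compound 1 now stands apart from all three other groups. No measurement shown here gives a reason for this difference. Still open, from the compounds shown here alone, is whether a small amine or a morpholine ring at this position would give a number nearer that of compound 1.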